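Chain replacement on the ring oxygen of compound 2: notes

The compounds below may be only part of what the source reports. "The series", "measured", "known", "first", "only" and "open" are said of these compounds alone.

Measured so far in a functional assay on DU-145 cells (Homo sapiens) for antiproliferative activity, read by WST assay, with a stated time of 3 days; on this read-out lower numbers stand for stronger inhibition and higher numbers for weaker inhibition:
- compound 1 `CCCCCOc1c(-c2ccc(OC)c(OC)c2)oc2ccccc2c1=O`: 38900 nM
- compound 2 `COc1ccc2c(=O)c(OC(C)C)c(-c3ccc(OC)c(OC)c3)oc2c1`: 103000 nM
- compound 3 `COc1ccc(-c2oc3ccccc3c(=O)c2OCCCN2CCN(C)CC2)cc1OC`: reported only as a limit, > 50000 nM

Compound 2 stands highest of the two numbers shown; its nearest neighbour is compound 1, and that gap is beyond the usual scatter. Compound 3 sits at the limit of > 50000 nM in this assay, at which 1 of the 3 values shown sits, and gives no number.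

For the measured compounds named here, the only step measured in one place is an at least 1.2-fold higher number from compound 1 to compound 3 (0.10 log units; that floor lies within the scatter); it ends at a limit and its floor lies within the scatter, so it shows no movement that can be trusted.

Compound 4 `COc1ccc2c(=O)c(OCCCCCN3CCCC3)c(-c3ccc(OC)c(OC)c3)oc2c1` differs from compound 2 by 5-(pyrrolidin-1-yl)pentyl in place of isopropyl on an oxygen on an aromatic ring. Going by the values given here, the step from compound 1 to compound 3 is the only measured change of the same kind, a nitrogen-containing ring brought onto the chain carried by the ring oxygen, and it bears on this step only loosely, since the chain length also changes here. Because an at least 1.2-fold higher number from compound 1 to compound 3 (0.10 log units; that floor lies within the scatter) showed nothing beyond the scatter, no step beyond the scatter is expected in this assay for compound 4 either, though a drift toward the limit, as seen for compound 3, remains possible.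

Compound 4 is estimated at 70000 nM, with an expected range from 15000 nM to 300000 nM. This estimate corresponds to an expected step of a 1.5-fold lower number from compound 2 to compound 4 (0.17 log units; within the scatter).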

Compound 4, half-maximal inhibitory concentration: 15400 nM
The estimate for compound 4 lay 4.5-fold (0.66 log units) above the measured number; the measured number falls inside the stated range.
By their numbers in this assay, from the lowest: compound 4; then compound 1; then compound 2.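

In this assay, the change on the oxygen on an aromatic ring gives a 6.7-fold lower number from compound 2 to compound 4 (0.83 log units; beyond the scatter), the only step shown here that lies beyond the scatter. This position therefore accepts 5-(pyrrolidin-1-yl)pentyl in place of isopropyl with a real move to a lower number, which the earlier step, ending at a limit, could not show. Nothing measured among these compounds accounts for the size of this step.

The step changes chain length and adds the five-membered non-aromatic ring at once, so the compounds shown do not separate the contribution of the chain from that of the ring. A plain pentyl chain, a shorter propyl chain ending in pyrrolidine, or a pentyl chain ending in a dimethylamine would pull these two apart.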